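Working notes: tolerance of the shared core to chlorophenyl changes

The source may report more compounds than this note shows. Statements on the series, on what has been measured and on what is new or still open speak of the compounds shown alone.

Compound 1 `COc1ccccc1-c1nnc(-c2sc(-c3cccnc3)nc2C)o1` and compound 2 `Cc1nc(-c2cccnc2)sc1-c1nnc(-c2ccc(Cl)cc2)o1` share the same core and differ in one place. In an ADME assay on THP-1 cells (Homo sapiens) for cytotoxicity, read by MTT assay (on this read-out lower numbers stand for higher toxicity in this test and higher numbers for lower toxicity in this test), compound 1 gives > 100 ug/mL, which is a limit of the assay and not a number. In this assay compound 2 likewise gives > 100 ug/mL, again only a limit. The step that the two limits leave unreadable from compound 1 to compound 2 therefore cannot be read in size; both values sit at the limit of > 100 ug/mL in this assay, at which 2 of the 2 values shown sit. Compound 2 thus stands at the limit of the read-out, with no number of its own to compare against. Compound 3 `Cc1nc(-c2cccnc2)sc1-c1nnc(-c2cccc(Cl)c2Cl)o1` is the next member, still to be measured in this assay. Its change against compound 2 is 2,3-dichlorophenyl in place of 4-chlorophenyl on an aromatic carbon. Among the measured compounds shown here, the only measured step that bears on it, a step that the two limits leave unreadable from compound 1 to compound 2, exchanged one aryl group for another without moving the read-out off the limit, so no step beyond the scatter is expected from this change either. The expected step is accordingly a step that the limit leaves unreadable from compound 2 to compound 3. For compound 3 the estimate in this assay is 150 ug/mL, with a range from 60 ug/mL to 400 ug/mL, and most likely it will again be reported only as a limit.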

Compound 3, half-maximal cytotoxic concentration: > 100 ug/mL
Compound 3 ended at the assay's limit; the forecaster's own chance of this, stated with the estimate: 80%; the middle value lies beyond the limit too.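

The steps from compound 2 to compound 3 and from compound 1 to compound 3 cannot be read, since in this assay all three compounds give only a limit and not a number: the limit of > 100 ug/mL in this assay, at which 3 of the 3 values shown sit.

The compounds shown leave open whether any of these aryl groups on the shared core differ in cytotoxicity, and by how much.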